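From compound 2 to compound 3: ring size

A few compounds are considered here, and "the series" means these few. Any claim that something is new, unique, unknown or untested is made for them only; others in the source may bear on it.

Among the measured compounds shown here, in an ADME assay on the whole organism (Rattus norvegicus, strain Sprague-Dawley) for pharmacokinetics, read by LC-MS, with a stated time of 72 h, at a dose of 1 mg/kg by the intravenous route (on this read-out higher numbers stand for wider distribution into tissues and lower numbers for narrower distribution), compound 2 (`CN1CC[C@H](N(c2cc(C#CC(C)(C)C)sc2C(=O)O)C(=O)[C@H]2CC[C@H](C)CC2)C1=O`) gives 6.04 L/kg, the higher of the two numbers so far, while compound 1 (`CN1CC[C@@H](N(c2cc(C#CC(C)(C)C)sc2C(=O)O)C(=O)[C@H]2CC[C@H](C)CC2)C1=O`) gives 1.93 L/kg. For the measured compounds named here, the only measured step is a 3.1-fold higher number from compound 1 to compound 2 (0.50 log units; beyond the scatter), and the structural ground for it is the fact that compounds 1 and 2 differ only in the configuration as drawn.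

Compound 3 (`CN1CCCC[C@@H](N(c2cc(C#CC(C)(C)C)sc2C(=O)O)C(=O)[C@H]2CC[C@H](C)CC2)C1=O`) carries 1-methyl-2-oxoazepan-3-yl in place of 1-methyl-2-oxopyrrolidin-3-yl on an amide-type nitrogen. Going by the values given here, no measured step covers a change of ring size, so the step to compound 1 serves only as a rough guide to how far this assay moves within this pair. With compound 2 at the top of a narrow set, a tentative drift towards lower numbers is expected, probably not beyond the scatter. The expected step is a 1.7-fold lower number from compound 2 to compound 3 (0.24 log units; within the scatter). For compound 3 the estimate is 3.5 L/kg, with an expected range of 1.3 L/kg to 9 L/kg.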

Compound 3, volume of distribution at steady state: 1.05 L/kg
Estimate against measurement, compound 3: 3.3-fold (0.52 log units) above; the measured number lies below the stated range.
By their numbers in this assay, from the lowest: compounds 3 and 1 (each within the scatter of the next); then compound 2.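

In this assay, the position on the amide-type nitrogen responds to ring size as well as to configuration: with 1-methyl-2-oxoazepan-3-yl in place of 1-methyl-2-oxopyrrolidin-3-yl, the step is beyond the scatter when read against the higher reference (a 5.8-fold lower number from compound 2 to compound 3 (0.76 log units; beyond the scatter)). Read against the other reference, the same exchange stays within the scatter (a 1.8-fold lower number from compound 1 to compound 3 (0.26 log units; within the scatter)), so the size of this change cannot be stated without naming its reference. The reading depends on the reference because the two five-membered compounds are separated by drawn configuration alone: the fact that compounds 1 and 2 differ only in the configuration as drawn

As far as these compounds go, it remains open whether 1-methyl-2-oxopiperidin-3-yl on the same nitrogen would give a number nearer compound 2 or compound 3. Also open, from the compounds shown here alone, is whether the opposite drawn configuration of 1-methyl-2-oxoazepan-3-yl would move the number in this assay as configuration does in the five-membered pair.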